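Benzoyl at the ring nitrogen, carried to a second core

The compounds below may be only part of what the source reports. "The series", "measured", "known", "first", "only" and "open" are said of these compounds alone.

Compound 1 `O=C(Nc1ccccc1C(F)(F)F)C1CCc2ccccc2N1` and compound 2 `O=C(Nc1ccccc1C(F)(F)F)C1CCc2ccccc2N1C(=O)c1ccccc1` share one core; compound 3 `O=C(Nc1cc(C(F)(F)F)cc(C(F)(F)F)c1)C1CCc2ccccc2N1` and compound 4 `O=C(Nc1cc(C(F)(F)F)cc(C(F)(F)F)c1)C1CCc2ccccc2N1C(=O)c1ccccc1` share another. The difference between the two cores is not broken down here.

In a functional assay on HCT-15 cells (Homo sapiens) for cytotoxicity, read by sulforhodamine B assay, with a stated time of 72 h (on this read-out lower numbers stand for stronger inhibition of growth and higher numbers for weaker inhibition of growth), compound 1 gives 40400 nM and compound 2 gives 6500 nM. The change between them is benzoyl in place of hydrogen on a nitrogen on an aromatic ring in a ring and the step is a 6.2-fold lower number from compound 1 to compound 2 (0.79 log units; beyond the scatter). Compound 3 gives 8700 nM in this assay; its gap to compound 2 is within the scatter, its gap to compound 1 beyond it.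

Compound 4 is not yet measured. It carries benzoyl in place of hydrogen on a nitrogen on an aromatic ring in a ring, the same kind of change as that from compound 1 to compound 2, and the two places are described in the same words. The step from compound 3 to compound 4 in this assay is expected to be a 4.8-fold lower number from compound 3 to compound 4 (0.68 log units; beyond the scatter), set slightly below the earlier one because a 6.2-fold lower number from compound 1 to compound 2 (0.79 log units; beyond the scatter) was modest and compound 3 already starts from a lower number than compound 1, so the full step may not carry over. Compound 4 is thus estimated at 1800 nM in this assay, expected between 600 nM and 6000 nM.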

Compound 4, concentration for 50% growth inhibition: 3540 nM
For compound 4 the middle estimate is 2.0-fold (0.29 log units) below the measured one, and the stated range covers the measured number.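

In this assay benzoyl in place of hydrogen on the nitrogen again gives a lower number on the second core, with a 2.5-fold lower number from compound 3 to compound 4 (0.39 log units; beyond the scatter). Set beside the earlier step, the two sizes do not separate: the same change on two cores in this assay, a 6.2-fold lower number (0.79 log units; beyond the scatter) from compound 1 to compound 2 and a 2.5-fold lower number (0.39 log units; beyond the scatter) from compound 3 to compound 4, 2.5-fold (0.40 log units) apart, within the scatter of two such steps. The change therefore carries over in direction and, within the scatter, in size across these two pairs, but two pairs set no rule for further cores and do not show why the number falls.

The compounds shown leave open whether the step depends on benzoyl itself or would also appear with another group on this nitrogen, such as acetyl, methyl or a longer alkyl chain. Also open, on these data alone, is how the step behaves on a core whose anilide ring carries something other than trifluoromethyl, such as a nitrile or a methoxy group.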